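The compounds below may be only part of what the source reports. "The series", "measured", "known", "first", "only" and "open" are said of these compounds alone.

Three compounds share one core and differ only in the aryl group on one urea nitrogen. Compound 1 `O=C(Nc1ccc(Oc2ncnc3[nH]ncc23)cc1)Nc1ccc(C(F)(F)F)cc1` carries a 4-(trifluoromethyl)phenyl group there, and in an assay on isolated protein for inhibition of vascular endothelial growth factor receptor 2 (Danio rerio), read by fluorescence and microscopy, with a stated time of 33 h (on this read-out lower numbers stand for stronger inhibition and higher numbers for weaker inhibition), compound 1 gives 1200 nM. Compound 2 `O=C(Nc1ccc(Oc2ncnc3[nH]ncc23)cc1)Nc1cccnc1` carries a pyridin-3-yl group instead, and in this assay compound 2 reaches only a limit, > 100000 nM. Compound 3 `CC(C)c1cccc(NC(=O)Nc2ccc(Oc3ncnc4[nH]ncc34)cc2)c1` carries a 3-isopropylphenyl group and gives 7730 nM. Among the numbers shown, compound 1 stands lowest: a 6.4-fold higher number from compound 1 to compound 3 (0.81 log units; beyond the scatter), and an at least 83-fold higher number from compound 1 to compound 2 (1.92 log units; beyond the scatter), where the value of compound 2 sits at the limit of > 100000 nM in this assay, at which 1 of the 3 values shown sits.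

Compound 4 `O=C(Nc1ccc(Oc2ncnc3[nH]ncc23)cc1)Nc1ccc(C(F)(F)F)cc1Cl` is not yet measured. It keeps the 4-(trifluoromethyl)phenyl group of compound 1 and adds a single group: chloro in place of hydrogen on an aromatic carbon, on an aromatic carbon of a six-membered aromatic ring of carbon only, ortho to a large group and meta to a trifluoromethyl group. For the measured compounds named here, none of the measured steps adds a substituent to an otherwise unchanged ring; each swaps the whole aryl group. They show that this assay answers strongly to what sits on that nitrogen, but give no direction for a small addition. Compound 4 is therefore expected to stay close to compound 1, with an estimated 1.7-fold lower number from compound 1 to compound 4 (0.23 log units; within the scatter). The estimate for compound 4 is 700 nM, within 200 nM to 2500 nM.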

Compound 4, half-maximal inhibitory concentration: 8460 nM
The estimate for compound 4 lay 12-fold (1.08 log units) below the measured number; the whole stated range lies below it.
By their numbers in this assay, from the lowest: compound 1; then compounds 3 and 4 (each within the scatter of the next). At a limit, above all of these: compound 2.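

In this assay, adding a single chloro to the aryl ring on the urea nitrogen gives a 7.1-fold higher number from compound 1 to compound 4 (0.85 log units; beyond the scatter), so this small addition has a clear effect on the read-out. For the compounds shown here, every earlier step swapped the whole aryl group, which showed only that the choice of group on that nitrogen matters. Here the 4-(trifluoromethyl)phenyl group stays in place, and one extra heavy atom on an aromatic carbon, ortho to a large group and meta to a trifluoromethyl group, is enough to move the number beyond the scatter, so this position is not free to take a substituent without consequence; nothing in the data shown explains why this one atom has such an effect.

From the compounds shown here alone, it remains open whether this rise belongs to chloro itself or would also follow with fluoro, a methyl group or a methoxy group on the same carbon. Also open, going by these compounds, is whether chloro on a different carbon of this ring would move the number in the same direction, and whether the same addition would act alike on the 3-isopropylphenyl group of compound 3.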